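Arylpiperazine succinimide amides in the maximal electroshock model

The source may hold more compounds than are shown below. What is called first, only, known or untested is meant among the compounds shown, and "the series" means these compounds.

Measured so far:
compound 1, `COc1cccc(N2CCN(C(=O)C(C)N3C(=O)CCC3=O)CC2)c1`, 0%
compound 2, `CCC(C(=O)N1CCN(c2ccccc2Cl)CC1)N1C(=O)CCC1=O`, 50%
compound 3, `CCC(C(=O)N1CCN(c2ccc(C(F)(F)F)cc2)CC1)N1C(=O)CCC1=O`, 0%

Three compounds sharing one core were tested in a functional assay on the whole organism (strain Swiss) with Mus musculus as the target, in the maximal electroshock model, with a stated time of 1 h, at a dose of 300 mg/kg by the intraperitoneal route; a higher number here means a stronger effect of the compound at the dose given, a lower number a weaker effect. Compound 1 gives 0%, and compound 3 gives 0%; these two values are level within the scatter and together form the lowest of the three numbers. Compound 2 stands apart: in this assay compound 2 gives 50%, the only clear effect seen, a gap from compound 1 that lies well beyond the scatter.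

The next compound, compound 4, is `CC(C(=O)N1CCN(c2ccc(F)cc2)CC1)N1C(=O)CCC1=O`. It differs from compound 1 in one place: 4-fluorophenyl in place of 3-methoxyphenyl on an amine nitrogen in a ring. Going by the values given here, since no pair of compounds that differ in a single place has been measured, no step is known from the data, and the only guide is that compound 1 and compound 3 both show no effect while compound 2 alone responds. The step from compound 1 to compound 4 is therefore expected to be small, upward if anything, and most likely not beyond the scatter, as a number 10 percentage points higher from compound 1 to compound 4 (within the scatter). Compound 4 is estimated at 10%, within a range from 0% to 40%.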

Compound 4, a percentage reported as activity, at one dose (the size of the read-out at that dose, not a potency): 25%
Compound 4: the middle estimate sits 15 percentage points below what was measured; the range from low to high includes it.
By their numbers in this assay, from the lowest: compounds 1 and 3 (each within the scatter of the next); then compound 4; then compound 2.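

In this assay, going by these compounds alone, 4-fluorophenyl in place of 3-methoxyphenyl on an amine nitrogen in a ring gives a number 25 percentage points higher from compound 1 to compound 4 (beyond the scatter), the first step in this set that can be read from a change in one place. Within the data shown here, it shows that, with the rest of the core of compound 1 held fixed, the aryl group at this position can by itself move the read-out, which the earlier compounds, differing in more than one place, could not show. No measurement available here bears on why this step occurs.

From the compounds shown here alone, it remains open whether the gain follows from the fluorine or from the loss of the methoxy group, a question that an unsubstituted phenyl group at this position would address. As the read-out comes from one dose, the step also leaves the relative potency of these two compounds open.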